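Biaryl pyrazole acids: cyano replacing trifluoromethoxy

The source may hold more compounds than are shown below. What is called first, only, known or untested is meant among the compounds shown, and "the series" means these compounds.

The series shares a pyrazole carboxylic acid core carrying a methyl group and a benzylic link to an aromatic portion; compound 1 `Cc1n[nH]c(C(=O)O)c1Cc1ccc2ccccc2n1` has a bicyclic aromatic, whereas compound 2 `Cc1n[nH]c(C(=O)O)c1Cc1cccc(-c2cccc(F)c2)c1` and compound 3 `Cc1n[nH]c(C(=O)O)c1Cc1cccc(-c2ccc(OC(F)(F)F)cc2)c1` carry a biaryl. In an assay on isolated protein for inhibition of 2-Hydroxyacid oxidase 2 (Homo sapiens), tested at 1 uM (a lower number here means a weaker effect, a higher number a stronger effect of the compound at the concentration tested), compound 1 gives 2%. Compound 2 gives 20% in this assay. Compound 3 gives 6% in this assay, the second highest of the three numbers; its nearest neighbour is compound 1, whose number lies within the scatter of that of compound 3, while compound 2 stands beyond the scatter above compound 3.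

Compound 4 `Cc1n[nH]c(C(=O)O)c1Cc1cccc(-c2ccc(C#N)cc2)c1` differs from compound 3 by one change (cyano in place of trifluoromethoxy on an aromatic carbon), on an aromatic carbon of a six-membered aromatic ring of carbon only, para to a large group. Going by the values given here, no measured pair in the set isolates this change, so the direction is not anchored by data; the two biaryl numbers, compound 2 and compound 3, show only that substitution on the outer ring can shift the read-out in either direction. A step from compound 3 to compound 4 of a number 4 percentage points higher from compound 3 to compound 4 (within the scatter) is expected, that is none beyond the scatter. Compound 4 is therefore estimated at 10% in this assay, with a range from 0% to 28%.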

Compound 4, a percentage reported as inhibition, at one concentration (the size of the read-out at that concentration, not a potency): 13%
For compound 4 the middle estimate is 3 percentage points below the measured one; low and high end bracket the measured number.
By their numbers in this assay, from the lowest: compounds 1, 3, 4 and 2 (each within the scatter of the next, the first and the last beyond it).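

In this assay, going by these compounds alone, cyano in place of trifluoromethoxy on an aromatic carbon, para to a large group, gives a number 7 percentage points higher from compound 3 to compound 4 (within the scatter); this is the first measured pair to isolate the change, and it shows that replacing a group of 5 heavy atoms with one of 2 heavy atoms at this place moves the read-out by no more than the usual scatter. The second comparison, 4-cyanophenyl in place of 3-fluorophenyl on an aromatic carbon, gives a number 7 percentage points lower from compound 2 to compound 4 (within the scatter), so at a single tested concentration compound 4 cannot be separated from either of these two biaryl neighbours. No measurement shown here bears on why the read-out stays within the scatter across these two changes.

Still open, from the compounds shown here alone, is whether a different group at this place, such as an amine, a carboxylic acid or a longer chain, would carry the read-out beyond the scatter from compound 3. The exchange of 3-fluorophenyl for 4-cyanophenyl also alters the substituent and its place on the ring together, so the contribution of each remains unresolved.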